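A few compounds are considered here, and "the series" means these few. Any claim that something is new, unique, unknown or untested is made for them only; others in the source may bear on it.

In a functional assay on ECa-109 cells (Homo sapiens) for cytotoxicity, read by MTT assay, with a stated time of 72 h (a lower number here means a stronger inhibitor, a higher number a weaker inhibitor), compound 2 (`COCOc1cc(/C=C/C(=O)OCC(=O)NCc2ccco2)ccc1OCc1ccccc1`) gives only a limit, > 200000 nM, and not a number. Compound 1 (`COc1ccc(/C=C/C(=O)OCC(=O)Nc2ccccc2)cc1OC`) likewise returns only a limit, > 200000 nM. Compound 3 (`CCOc1ccc(COc2c(OC)cc(/C=C/C(=O)OCC(=O)Nc3ccccc3)cc2OC)cc1`) also returns only a limit, > 200000 nM. Compound 2 therefore stands with the other two at the edge of what the assay reports, as set out in the limit of > 200000 nM in this assay, at which 3 of the 3 values shown sit. Compound 4 (`COCOc1cc(/C=C/C(=O)OCC(=O)Nc2ccc(Cl)cc2)ccc1OCc1ccccc1`) differs from compound 2 by 4-chlorophenyl in place of (furan-2-yl)methyl on an amide-type nitrogen. For the measured compounds named here, no measured step accompanies this change, and every measured compound sits at the limit, so nothing here points to a shift beyond the scatter in this assay. Compound 4 is expected to give another limit. Compound 4 is accordingly estimated at 200000 nM, within 100000 nM to 400000 nM, an expected step of a number no higher from compound 2 to compound 4 (the limit leaves the size open).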

Compound 4, half-maximal inhibitory concentration: > 200000 nM
Compound 4 gave a limit, no number; the forecaster's own chance of this, stated with the estimate: 80%; the middle value lies on the limit itself.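

In this assay compound 4 gives only a limit, > 200000 nM. For the compounds shown here, compound 2 is also a limit, so no step between compound 2 and compound 4 can be read. The compounds shown leave open whether any of these changes alters cytotoxicity at all: the limit of > 200000 nM in this assay, at which 4 of the 4 values shown sit.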